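Chain length at the carbamate oxygen: compound 3 to compound 4

This account rests on a few compounds, and the source may have more. Where it says the series, first, only, none or still open, it means among the compounds named here.

Measured in a functional assay on CCRF-CEM cells (Homo sapiens) for cytotoxicity, read by MTT assay, with a stated time of 72 h; on this read-out higher numbers stand for weaker inhibition of growth and lower numbers for stronger inhibition of growth:
- compound 1 `CCCOC(=O)Nc1ccc([Se]C#N)cc1` gives 9300 nM
- compound 2 `CCCCOC(=O)Nc1ccc([Se]C#N)cc1` gives 6500 nM
- compound 3 `C=CCOC(=O)Nc1ccc([Se]C#N)cc1` gives 9200 nM

Compound 3 sits among three numbers that all lie within the scatter of one another; its nearest neighbour is compound 1 and the step of a 1.0-fold lower number from compound 1 to compound 3 (0.00 log units; within the scatter) is flat. Among the compounds with values here, the step of a 1.4-fold higher number from compound 2 to compound 3 (0.15 log units; within the scatter) is also within the scatter, as is a 1.4-fold lower number from compound 1 to compound 2 (0.16 log units; within the scatter), so nothing among the measured compounds separates one chain at the carbamate oxygen from another.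

Compound 4 `CCCCCCOC(=O)Nc1ccc([Se]C#N)cc1` is not yet measured. It differs from compound 3 by pentyl in place of vinyl on a saturated chain carbon bound to an oxygen next to a carbonyl group. Within the data shown here, the steps that bear on it are the chain changes above, none of which moved the number beyond the scatter. The expectation for compound 4 is therefore a step of a 1.5-fold lower number from compound 3 to compound 4 (0.19 log units; within the scatter), at most a small lowering in this assay in the direction hinted at by a 1.4-fold lower number from compound 1 to compound 2 (0.16 log units; within the scatter), with no change beyond the scatter the most likely outcome. Compound 4 is accordingly estimated at 6000 nM, with a range from 2500 nM to 15000 nM.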

Compound 4, concentration for 50% growth inhibition: 19700 nM
Compound 4: the middle estimate sits 3.3-fold (0.52 log units) below what was measured; measured number above the stated range.
By their numbers in this assay, from the lowest: compounds 2, 3 and 1 (each within the scatter of the next); then compound 4.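

Within the data shown here, this position is not indifferent to the chain: in this assay, the hexyl chain gives the first changes beyond the scatter, a 2.1-fold higher number from compound 3 to compound 4 (0.33 log units; beyond the scatter) and a 2.1-fold higher number from compound 1 to compound 4 (0.33 log units; beyond the scatter). Against the butyl chain, the step reads a 3.0-fold higher number from compound 2 to compound 4 (0.48 log units; beyond the scatter), so lengthening does not carry on in the direction of a 1.4-fold lower number from compound 1 to compound 2 (0.16 log units; within the scatter), a step that never left the scatter. No measurement shown here accounts for this rise.

Open, on these data alone, is where the change sets in between the butyl and hexyl chains, which a pentyl chain would help to place, and whether a longer chain such as octyl or decyl raises the number further. Also open, as far as these compounds go, is how a chain ending in an amine or a carboxylic acid would read at this position.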